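The amide side chain of compound 2 replaced

The source may report more compounds than this note shows. Statements on the series, on what has been measured and on what is new or still open speak of the compounds shown alone.

- compound 1 `O=C(NCCCc1ccncc1)C1CCN(C(=O)c2cc3ccccc3n2Cc2ccc(Cl)cc2)CC1`: 16000 nM
- compound 2 `O=C(NCCn1ccnc1)C1CCN(C(=O)c2cc3ccccc3n2Cc2ccc(Cl)cc2)CC1`: 31000 nM

Within the data shown here, in a physicochemical assay for solubility, measured as kinetic solubility (a higher number here means a more soluble compound, a lower number a less soluble compound), compound 2 stands level with compound 1, the only other compound measured: a 1.9-fold higher number from compound 1 to compound 2 (0.29 log units; within the scatter). Compound 3 `CN(C)C(=O)C1CCN(C(=O)c2cc3ccccc3n2Cc2ccc(Cl)cc2)CC1` keeps the shared core and differs from compound 2 at one place: dimethylamino in place of (2-(1H-imidazol-1-yl)ethyl)amino on a carbonyl carbon. Among the measured compounds shown here, the single measured step swapped one ring-bearing chain end for another, whereas the group entering compound 3 has no ring, so that step offers only a weak guide. A modest fall is expected, with real uncertainty: the estimated step is a 2.1-fold lower number from compound 2 to compound 3 (0.32 log units; beyond the scatter). For compound 3 the estimate is 15000 nM, with an expected range of 4000 nM to 45000 nM.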

Compound 3, solubility: 62000 nM
Compound 3: middle estimate off by 4.1-fold (0.62 log units), on the low side, outside the stated range (above it).
By their numbers in this assay, from the lowest: compounds 1, 2 and 3 (each within the scatter of the next, the first and the last beyond it).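

In this assay, dimethylamino on the carbonyl carbon stays level with the (2-(1H-imidazol-1-yl)ethyl)amino of compound 2 (a 2.0-fold higher number from compound 2 to compound 3 (0.30 log units; within the scatter)) but stands clear of the (3-(pyridin-4-yl)propyl)amino of compound 1 (a 3.9-fold higher number from compound 1 to compound 3 (0.59 log units; beyond the scatter)). This position therefore accepts a group with no ring and no hydrogen-bond donor, which the two ring-bearing chain ends could not show. Nothing available explains this result. The compounds shown leave open how a morpholine amide or a primary amide would read at this carbonyl carbon.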